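A few compounds are considered here, and "the series" means these few. Any claim that something is new, unique, unknown or untested is made for them only; others in the source may bear on it.

Compound 3 `Cc1ccc2[nH]c(=O)c(CN(Cc3ccc(C(C)(C)C)cc3)[C@@H](C)c3ccc(F)cc3)cc2c1` stands only at a limit: in a toxicity assay on MDCK cells (Canis lupus familiaris) for cytotoxicity, read by crystal violet staining, with a stated time of 48 h (a lower number here means that less compound is tolerated, a higher number that more compound is tolerated), compound 3 gives > 5000 nM, which is a limit rather than a number. Its two comparators are in the same position. Compound 1 `CCOc1ccc(CN(Cc2ccc(C(C)(C)C)cc2)Cc2cc3cc(C)ccc3[nH]c2=O)cc1` gives in this assay > 10000 nM, a limit. Compound 2 `Cc1ccc2[nH]c(=O)c(CN(Cc3ccc(OC(C)C)cc3)Cc3ccc(C(C)(C)C)cc3)cc2c1` gives in this assay > 5000 nM, again a limit. The three single-point steps, a step that the two limits leave unreadable from compound 1 to compound 2, a step that the two limits leave unreadable from compound 1 to compound 3 and a step that the two limits leave unreadable from compound 2 to compound 3, are therefore unreadable in size and direction because the limit of > 10000 nM in this assay, at which 1 of the 3 values shown sits, and the limit of > 5000 nM in this assay, at which 2 of the 3 values shown sit, hold every value shown at a limit. None of the three changes, whether methyl in place of hydrogen on the saturated chain carbon bound to the aromatic oxygen or the exchange of one arm on the amine nitrogen, has revealed any tolerated-concentration change in this assay.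

Compound 4 `COc1ccc(C(C)N(Cc2ccc(C(C)(C)C)cc2)Cc2cc3cc(C)ccc3[nH]c2=O)cc1Cl` differs from compound 3 by 1-(3-chloro-4-methoxyphenyl)ethyl in place of 1-(4-fluorophenyl)ethyl on an amine nitrogen. Among the compounds with values here, no measured step reads a size for a change of this kind, and the whole set sits at limits, so no step beyond the scatter is expected; the step that the limit leaves unreadable from compound 3 to compound 4 is the expectation. Compound 4 is accordingly estimated in this assay at 8000 nM, within 3000 nM to 20000 nM, most likely reported again as a limit.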

Compound 4, half-maximal cytotoxic concentration: > 10000 nM
Compound 4: no number, only a limit; the forecaster's own chance of this, stated with the estimate: 75%; middle value at least 1.2-fold (0.09 log units) away from the limit.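

In this assay compound 4 gives > 10000 nM, which is a limit. Its steps from compound 1, compound 2 and compound 3 cannot be read in size or direction. The compounds shown leave open the concentration at which any of these four becomes cytotoxic, and whether exchanging an arm on the amine nitrogen changes it.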